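The source may hold more compounds than are shown below. What is called first, only, known or untested is meant among the compounds shown, and "the series" means these compounds.

Working notes. In an assay on CHO cells with 5-hydroxytryptamine receptor 1D (Homo sapiens) as the target (a higher number here means a weaker inhibitor, a lower number a stronger inhibitor), compound 3 `CN(CC1CCCCC1)CC1(O)CCN(CCCc2c[nH]c3ccc(-n4cnnc4)cc23)CC1` gives 1.2 nM, the lowest of the three numbers, though compound 1 `CN(CC(C)(C)C)CC1(O)CCN(CCCc2c[nH]c3ccc(-n4cnnc4)cc23)CC1` with 1.8 nM sits within the scatter of it; compound 2 `CC(C)(C)OC(=O)NCC1(O)CCN(CCCc2c[nH]c3ccc(-n4cnnc4)cc23)CC1` gives 21 nM and is clearly weaker, as an 18-fold lower number from compound 2 to compound 3 (1.24 log units; beyond the scatter) and a 12-fold higher number from compound 1 to compound 2 (1.07 log units; beyond the scatter) show. Compound 4 `Cc1ccccc1CN(C)CC1(O)CCN(CCCc2c[nH]c3ccc(-n4cnnc4)cc23)CC1` differs from compound 3 by 2-methylphenyl in place of cyclohexyl on a saturated chain carbon bound to an amine nitrogen. Among the measured compounds shown here, the only measured step at that position is a 1.5-fold lower number from compound 1 to compound 3 (0.18 log units; within the scatter), a swap between saturated hydrocarbon groups on the same chain carbon; no measured step replaces a saturated ring by an aromatic one here. The expectation for compound 4 in this assay is therefore a step of a 1.3-fold higher number from compound 3 to compound 4 (0.12 log units; within the scatter), not beyond the scatter. Compound 4 is estimated at 1.6 nM, range 0.5 nM to 5 nM.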

Compound 4, half-maximal inhibitory concentration: 1.3 nM
The estimate for compound 4 lay 1.2-fold (0.09 log units) above the measured number; measured number inside the range.
By their numbers in this assay, from the lowest: compounds 3, 4 and 1 (each within the scatter of the next); then compound 2.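

In this assay, among the compounds shown here, an aromatic ring is accepted at this place, which no earlier step showed: 2-methylphenyl in place of cyclohexyl gives a 1.1-fold higher number from compound 3 to compound 4 (0.03 log units; within the scatter) and, against tert-butyl, a 1.4-fold lower number from compound 1 to compound 4 (0.14 log units; within the scatter) on a saturated chain carbon bound to an amine nitrogen. The new amine also stands well apart from the (tert-butoxycarbonyl)amino compound, with a 16-fold lower number from compound 2 to compound 4 (1.21 log units; beyond the scatter) for methyl(2-methylbenzyl)amino in its place. Nothing available explains why these steps fall as they do. The compounds shown leave open how a pyridine ring would read here, and whether a carboxylic acid on the aromatic ring would be accepted.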